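This account rests on a few compounds, and the source may have more. Where it says the series, first, only, none or still open, it means among the compounds named here.

Of the compounds shown here, three built on one shared core have so far been measured in a functional assay on K562 cells (Homo sapiens) for inhibition, read by sulforhodamine B assay, with a stated time of 48 h; a higher number here means a weaker inhibitor of growth, a lower number a stronger inhibitor of growth. Compound 1, `COc1cc(-c2cc(/C=C/C(=O)c3ccc(Cl)c(Cl)c3)[nH]n2)cc(OC)c1OC`, gives 64400 nM. Compound 2, `COc1ccc(-c2cc(/C=C/C(=O)c3ccc(N)cc3)[nH]n2)cc1OC`, gives 36400 nM, and compound 3, `COc1ccc(-c2cc(/C=C/C(=O)c3cc(OC)c(OC)c(OC)c3)[nH]n2)cc1OC`, gives 9710 nM. Among these three numbers compound 1 sits at the top end: the number for compound 2 lies within the usual scatter of it, so no order between those two can be read, whereas the number for compound 3 lies well beyond the scatter and shows clearly stronger inhibition of growth.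

Compound 4, `COc1ccc(C(=O)/C=C/c2cc(-c3cc(OC)c(OC)c(OC)c3)n[nH]2)cc1OC`, has not yet been measured. It differs from compound 1 in a single place: 3,4-dimethoxyphenyl in place of 3,4-dichlorophenyl on a carbonyl carbon. For the measured compounds named here, no measured pair differs in exactly this way, so any expectation must rest on the three numbers alone. Because compound 3 gives 9710 nM while compound 1 gives 64400 nM, a move toward methoxy-bearing rings appears to go with lower numbers, and the expected step of a 3.2-fold lower number from compound 1 to compound 4 (0.51 log units; beyond the scatter) in this assay is a lowering beyond the scatter. Compound 4 is estimated to give about 20000 nM, with a likely range from 6000 nM to 60000 nM.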

Compound 4, concentration for total growth inhibition: 7120 nM
Compound 4: middle estimate off by 2.8-fold (0.45 log units), on the high side, and the stated range covers the measured number.
By their numbers in this assay, from the lowest: compounds 4 and 3 (each within the scatter of the next); then compounds 2 and 1 (each within the scatter of the next).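

In this assay, exchanging 3,4-dichlorophenyl for 3,4-dimethoxyphenyl gives a 9.0-fold lower number from compound 1 to compound 4 (0.96 log units; beyond the scatter), and the rest of the molecule stays the same. For the compounds shown here, until now, no measured pair showed this exchange by itself, so the link between methoxy-bearing rings and lower numbers was only a loose impression drawn from compounds that did not form such a pair. This pair shows that the group on the carbonyl carbon can by itself move the number beyond the usual scatter, although nothing here explains the size of the step or shows whether losing the two chlorine atoms or gaining the two oxygen atoms matters more, and no supporting evidence bears on the result.

The compounds shown leave open how much of the step depends on having both methoxy groups, and a phenyl ring carrying one methoxy group, two hydroxyl groups or two methyl groups would help separate these possibilities. They also leave open whether the same exchange would give a similar step if the 3,4-dimethoxyphenyl were paired with a different group elsewhere on the shared core.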